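The compounds below may be only part of what the source reports. "The series", "measured", "known", "first", "only" and "open" are said of these compounds alone.

Measured compounds in a functional assay on HepG2 cells (Homo sapiens) for inhibition, read by MTT assay, with a stated time of 24 h; on this read-out lower numbers stand for stronger inhibition and higher numbers for weaker inhibition:

- compound 1 `CC1(C)[C@H]2CC[C@]1(C)N(Cc1cn(-c3ccccc3Br)nn1)C(=O)C2`: 150 nM
- compound 2 `CC1(C)[C@H]2CC[C@]1(C)N(Cc1cn(-c3ccccc3C#N)nn1)C(=O)C2`: 180 nM
- compound 3 `CC1(C)[C@H]2CC[C@]1(C)N(Cc1cn(-c3cccc(C#N)c3)nn1)C(=O)C2`: 40 nM

Compound 1 sits second highest of the three numbers. Its nearest neighbour is compound 2, with a 1.2-fold higher number from compound 1 to compound 2 (0.08 log units; within the scatter), a step within the scatter, so the two are not ordered. The furthest is compound 3, reached by a 3.8-fold lower number from compound 1 to compound 3 (0.57 log units; beyond the scatter), a modest step beyond the scatter.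

Compound 4 `CC1(C)[C@H]2CC[C@]1(C)N(Cc1cn(-c3ccc(Br)cc3)nn1)C(=O)C2` is the next compound for this assay. It differs from compound 1 as follows: 4-bromophenyl in place of 2-bromophenyl on an aromatic nitrogen

Within the data shown here, the step that bears most directly on this change is the one from compound 2 to compound 3, a 4.5-fold lower number from compound 2 to compound 3 (0.65 log units; beyond the scatter), where the same substituent is kept and only its placing on the phenyl ring changes, giving a modest lowering. The step from compound 1 to compound 3, a 3.8-fold lower number from compound 1 to compound 3 (0.57 log units; beyond the scatter), changes both the substituent and its placing, so it speaks less cleanly. Among the measured compounds shown here, no measured compound carries a 4-bromophenyl, so the expectation rests on the 2-cyanophenyl to 3-cyanophenyl comparison alone, and a 4-bromophenyl need not behave like a 3-cyanophenyl.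

Compound 4 is therefore expected to give a modestly lower number than compound 1, estimated at 80 nM with a range of 30 nM to 250 nM, which corresponds to an expected step of a 1.9-fold lower number from compound 1 to compound 4 (0.27 log units; within the scatter).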

Compound 4, half-maximal inhibitory concentration: 110 nM
Compound 4: the middle estimate sits 1.4-fold (0.14 log units) below what was measured; the range from low to high includes it.
By their numbers in this assay, from the lowest: compound 3; then compounds 4, 1 and 2 (each within the scatter of the next).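

Working notes on the aryl group on the triazole nitrogen: in this assay, the first comparison that moves bromine alone, from 2-bromophenyl to 4-bromophenyl, gives a 1.4-fold lower number from compound 1 to compound 4 (0.13 log units; within the scatter), so these two placings are not ordered, and a dependence on placing seen with the nitrile does not appear for this bromine pair. The 3-cyanophenyl compound stays apart from the new compound, with a 2.8-fold higher number from compound 3 to compound 4 (0.44 log units; beyond the scatter), whereas the 2-cyanophenyl compound does not separate from it, with a 1.6-fold lower number from compound 2 to compound 4 (0.21 log units; within the scatter); the three compounds carrying 2-bromophenyl, 4-bromophenyl and 2-cyanophenyl thus form one group, and only compound 3 lies clearly lower. Nothing on hand explains these differences or their absence.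

The compounds shown do not tell whether the lower number of compound 3 belongs to the nitrile, to its placing, or to the two together, and 3-bromophenyl and 4-cyanophenyl would separate these readings. As far as these compounds go, it also remains open how the unsubstituted phenyl, or a phenyl bearing an amine or a carboxylic acid, would stand against these four.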